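Carbonyl substituent swap in a triarylethylene series

The compounds below may be only part of what the source reports. "The series", "measured", "known", "first", "only" and "open" are said of these compounds alone.

In a functional assay on MDA-MB-231 cells (Homo sapiens) for cytotoxicity, read by MTT assay, with a stated time of 72 h (on this read-out lower numbers stand for stronger inhibition and higher numbers for weaker inhibition), compound 1 `COc1ccc(/C(=C(/CCNC(=O)N2CCOCC2)c2ccccc2)c2ccccc2)cc1` gives 42800 nM. Compound 2 `COc1ccc(/C(=C(/CCNC(=O)N2CCCCC2)c2ccccc2)c2ccccc2)cc1` returns only a limit in this assay, > 50000 nM, sitting at the limit of > 50000 nM in this assay, at which 1 of the 2 values shown sits. Among the measured compounds shown here, the only measured change at the carbonyl carbon, an at least 1.1-fold higher number from compound 1 to compound 2 (0.06 log units; that floor lies within the scatter), lies within the scatter. Compound 3 `COc1ccc(/C(=C(/CCNC(=O)C(=O)NC2CCCCC2)c2ccccc2)c2ccccc2)cc1` differs from compound 2 by cyclohexylcarbamoyl in place of piperidin-1-yl on a carbonyl carbon. For the measured compounds named here, no measured step covers this change; since the one change at this position stayed within the scatter, no step beyond the scatter is expected. The expected step is an at least 1.1-fold lower number from compound 2 to compound 3 (0.04 log units; that floor lies within the scatter). For compound 3 in this assay the estimate is 45000 nM, expected between 15000 nM and 150000 nM.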

Compound 3, half-maximal inhibitory concentration: 12200 nM
Compound 3: middle estimate off by 3.7-fold (0.57 log units), on the high side, and the stated range ends above it.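

The position does respond: in this assay, cyclohexylcarbamoyl on the carbonyl carbon gives an at least 4.0-fold lower number from compound 2 to compound 3 (0.61 log units; beyond the scatter), and also a 3.5-fold lower number from compound 1 to compound 3 (0.55 log units; beyond the scatter). The earlier swap of morpholin-4-yl for piperidin-1-yl gave no step beyond the scatter. The first of these two steps is only a floor, as its starting value is a limit: the limit of > 50000 nM in this assay, at which 1 of the 3 values shown sits.

The ring of carbon only, the hydrogen-bond donor and the hydrogen-bond acceptor enter together, and the compounds shown do not separate them. From the compounds shown here alone, whether phenylcarbamoyl or tert-butylcarbamoyl on the same carbonyl carbon would keep the step remains open.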